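Swapping chloro for methoxy on a sulfonamide-proline anilide

This account rests on a few compounds, and the source may have more. Where it says the series, first, only, none or still open, it means among the compounds named here.

In an ADME assay on HEp-2 cells (Homo sapiens) for cytotoxicity (a lower number here means that less compound is tolerated, a higher number that more compound is tolerated), three compounds have been measured. Compound 1, `Cc1ccc(Cl)cc1NC(=O)[C@@H]1CCCN1S(=O)(=O)c1cccc2cccnc12`, gives 10000 nM. Compound 2, `COc1ccc(C)c(NC(=O)[C@@H]2CCCN2S(=O)(=O)c2cccc3cccnc23)c1`, gives 44200 nM. Compound 3, `Cc1ccc(Cl)c(NC(=O)[C@@H]2CCCN2S(=O)(=O)c2cccc3cccnc23)c1`, gives > 50000 nM. For compound 3 that value is a limit of the assay, not a number.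

Compound 4, `COc1ccc(C)cc1NC(=O)[C@@H]1CCCN1S(=O)(=O)c1cccc2cccnc12`, is not yet measured; it differs from compound 3 by methoxy in place of chloro on an aromatic carbon. The same kind of change, (methoxy in place of chloro on an aromatic carbon), made the step of a 4.4-fold higher number from compound 1 to compound 2 (0.65 log units; beyond the scatter); the surroundings differ, since in compound 1 the place is meta to a large group and in compound 3 it is ortho to a large group. The two cores differ by 2-chloro-5-methylphenyl in place of 5-chloro-2-methylphenyl on an amide-type nitrogen, with the step of an at least 5.0-fold higher number from compound 1 to compound 3 (0.69 log units; beyond the scatter); compounds 2 and 3 are linked by an at least 1.1-fold higher number from compound 2 to compound 3 (0.05 log units; that floor lies within the scatter).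

The step from compound 3 to compound 4 is expected to be a step that the limit leaves unreadable from compound 3 to compound 4, resting on the step from compound 1 to compound 2 and on compound 3 already sitting at the limit of > 50000 nM in this assay, at which 1 of the 3 values shown sits. Compound 4 is therefore estimated at 120000 nM, between 45000 nM and 350000 nM, most likely reported again only as a limit.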

Compound 4, half-maximal cytotoxic concentration: > 50000 nM
Compound 4 gave a limit, no number; the forecaster's own chance of this, stated with the estimate: 85%; the middle value does not contradict the limit.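

In this assay compound 4 gives > 50000 nM, which is a limit and not a number. Compound 3 is also reported only as a limit, so the step from chloro to methoxy cannot be read on this core, and the change, which gave a 4.4-fold higher number from compound 1 to compound 2 (0.65 log units; beyond the scatter) on the other core, is neither confirmed nor refuted: the limit of > 50000 nM in this assay, at which 2 of the 4 values shown sit. Compound 4 does show an at least 5.0-fold higher number from compound 1 to compound 4 (0.69 log units; beyond the scatter), and an at least 1.1-fold higher number from compound 2 to compound 4 (0.05 log units; that floor lies within the scatter), but both steps also move groups around the ring, so neither measures the chloro-to-methoxy change itself.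

From the compounds shown here alone, the true values of compound 3 and compound 4 remain open. So does whether an amine or a carboxylic acid in place of the chloro would give a readable number on this core.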